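Working notes: replacing hydroxymethyl on the shared core

The source may hold more compounds than are shown below. What is called first, only, known or untested is meant among the compounds shown, and "the series" means these compounds.

Values so far in a functional assay on QG-56 cells (Homo sapiens) for antiproliferative activity; a higher number here means a weaker inhibitor, a lower number a stronger inhibitor
- compound 1 `COc1cccc(-c2cc(CO)cc3cc(C(O)(c4ccc(C#N)cc4)c4cncn4C)oc23)c1` gives 16.8 nM
- compound 2 `Cn1cncc1C(O)(c1ccc(C#N)cc1)c1cc2cc([N+](=O)[O-])cc(-c3ccccc3)c2o1` gives 1480 nM

Compound 1 at 16.8 nM holds the lower of the two numbers, and compound 2 at 1480 nM lies above it by a gap beyond the scatter. Within the data shown here, no two measured compounds differ in one place only, so no measured step is available to guide the next change.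

Compound 3 `COC(=O)c1cc(-c2cccc(OC)c2)c2oc(C(O)(c3ccc(C#N)cc3)c3cncn3C)cc2c1` is still to be measured in this assay and differs from compound 1 in one place: methoxycarbonyl in place of hydroxymethyl on an aromatic carbon meta to a 3-methoxyphenyl group. Among the measured compounds shown here, with compound 1 at 16.8 nM as the lower number so far, the change is expected to raise the number in this assay by a moderate step beyond the scatter, toward a weaker inhibitor. For the measured compounds named here, with only two measured compounds, the expectation is loose, and the estimate is an expected shift of a 5.4-fold higher number from compound 1 to compound 3 (0.73 log units; beyond the scatter) on thin evidence. For compound 3 the estimated value is 90 nM (expected range 22 nM to 400 nM).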

Compound 3, half-maximal inhibitory concentration: 36.3 nM
Compound 3: the middle estimate sits 2.5-fold (0.39 log units) above what was measured; the measured number falls inside the stated range.
By their numbers in this assay, from the lowest: compound 1; then compound 3; then compound 2.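

In this assay, among these compounds, this step is the first single-place comparison, and it shows that the aromatic carbon meta to a 3-methoxyphenyl group accepts methoxycarbonyl in place of hydroxymethyl at a modest cost: a 2.2-fold higher number from compound 1 to compound 3 (0.33 log units; beyond the scatter). The change takes this group from 1 hydrogen-bond donor to 0 and from 2 heavy atoms to 4, yet compound 3 still gives 36.3 nM, so a hydrogen-bond donor in this group is not required for a number of that order on the shared core. No measured evidence accounts for the size of the step.

A single step cannot separate the loss of the hydrogen-bond donor from the gain in heavy atoms or the added double bond, so which of these differences accounts for the shift remains unresolved. From the compounds shown here alone, how a carboxylic acid, a primary amide or an aminomethyl group on this same carbon would stand against compound 1 also remains open.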